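The compounds below may be only part of what the source reports. "The series", "measured", "known", "first", "only" and "open" are said of these compounds alone.

Of the compounds shown here, three have so far been tested in a functional assay on NCI/ADR-RES cells (Homo sapiens) for cytotoxicity, read by sulforhodamine B assay, with a stated time of 48 h, tested at 100 nM; a lower number here means a stronger effect, a higher number a weaker effect of the compound at the concentration tested. Compound 1, `COc1cc(C)cc(-c2c(-c3ccnc(-c4ccc(C(C)=O)cc4)c3)cnn2CC#N)c1`, gives 83% in this assay. Compound 2, `COc1cc(C)cc(-c2nn(CC#N)cc2-c2ccc(-c3cccc(C(C)=O)c3)nc2)c1`, gives 59% in this assay. Compound 3, `Cc1cc(O)cc(-c2nn(CC#N)cc2-c2ccnc(-c3ccc(Oc4ccccc4)cc3)c2)c1`, gives 95% in this assay, which is the highest of the three numbers and therefore the weakest effect at the concentration tested. The number nearest to that of compound 3 belongs to compound 1, and the gap between them lies beyond the usual scatter; the number of compound 2 lies furthest away, and that gap too lies beyond the scatter.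

Compound 4, `Cc1cc(O)cc(-c2nn(CC#N)cc2-c2ccnc(-c3ccc(N(C)C)cc3)c2)c1`, has not yet been measured. It differs from compound 3 in a single place: dimethylamino in place of phenoxy on an aromatic carbon. For the measured compounds named here, no measured pair in this set carries the same exchange, so nothing in the data shows how it moves the read-out, and the expectation rests on the starting number alone. Because compound 3 gives 95% in this assay, the starting point already sits near the weak end of the scale, leaving more room for the number to fall than to rise. The step of a number 10 percentage points lower from compound 3 to compound 4 (within the scatter) is expected to be small, towards a somewhat stronger effect, with a step within the scatter almost as likely. Compound 4 is estimated to give 85% in this assay, with a likely range from 60% to 100%.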

Compound 4, a percentage reported as activity, at one concentration (the size of the read-out at that concentration, not a potency): 91%
Beside the measured number, compound 4's estimate is 6 percentage points below it; measured number inside the range.
By their numbers in this assay, from the lowest: compound 2; then compounds 1, 4 and 3 (each within the scatter of the next, the first and the last beyond it).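

In this assay, dimethylamino in place of phenoxy on an aromatic carbon, para to a large group, gives a number 4 percentage points lower from compound 3 to compound 4 (within the scatter), so at this single concentration the two compounds cannot be told apart. For the compounds shown here, this is the first view of this position, and the exchange is not a subtle one: a group of 7 heavy atoms with a six-membered aromatic ring of carbon only gives way to a group of 3 heavy atoms with no ring, while the hydrogen-bond donor and acceptor counts stay the same. Even so, a large difference in the size of the group leaves no readable difference in the number, although no measurement shown here explains this result.

As far as these compounds go, it remains open whether a different kind of group at this position, such as a primary amine, a carboxylic acid or a longer alkoxy chain, would move the number beyond the scatter. From the compounds shown here alone, the exchange also appears only once, so whether it would read the same way on another core, or at another concentration, is still unknown.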